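Writhing-test inhibition: tert-butyl for methyl on the core

A few compounds are considered here, and "the series" means these few. Any claim that something is new, unique, unknown or untested is made for them only; others in the source may bear on it.

Measured compounds:
compound 1 `CCN1CCc2c(c(C)nn2C(=O)Nc2cc(C)ccc2C)C1`: 62.2%
compound 2 `CCN1CCc2c(c(C)nn2C(=O)Nc2cc(C)ccc2F)C1`: 10.5%

Among the measured compounds shown here, in a functional assay on the whole organism (strain Swiss albino) for inhibition, with Mus musculus as the target, in the writhing test, with a stated time of 30 min, at a dose of 100 mg/kg (on this read-out higher numbers stand for more inhibition at the one dose given (going by the name of the read-out) and lower numbers for less inhibition), compound 1 stands highest of the two numbers; the only measured step, a number 51.7 percentage points lower from compound 1 to compound 2 (beyond the scatter), concerns a change at a different place from the one now at issue. Compound 3 `CCN1CCc2c(c(C(C)(C)C)nn2C(=O)Nc2cc(C)ccc2C)C1` differs from compound 1 by tert-butyl in place of methyl on an aromatic carbon. For the measured compounds named here, no measured step bears on this change, so its direction and size cannot be read from the data. Compound 3 is therefore expected near compound 1, with a wide range either way: an estimated step of a number 17.2 percentage points lower from compound 1 to compound 3 (beyond the scatter), giving 45% (range 12% to 72%).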

Compound 3, a percentage reported as inhibition, in the whole organism at one dose (the size of the read-out at that dose, not a potency): 63.1%
The estimate for compound 3 lay 18.1 percentage points below the measured number; measured number inside the range.
By their numbers in this assay, from the lowest: compound 2; then compounds 1 and 3 (each within the scatter of the next).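

In this assay, tert-butyl in place of methyl on this aromatic carbon gives a number 0.9 percentage points higher from compound 1 to compound 3 (within the scatter), so the position takes the bulkier-by-count alkyl group without a difference that can be told from the scatter. Among the compounds shown here, this is the first reading at this position; the earlier step concerned a different place on the molecule. Nothing available accounts for this result.

Going by these compounds, whether an amine, a carboxylic acid or a phenyl group at this position would give similar inhibition stays open. So does whether compound 1 and compound 3 would also match at other doses.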